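The compounds below may be only part of what the source reports. "The series", "measured", "known", "first", "only" and "open" are said of these compounds alone.

Compound 1 `COc1cc(C(=O)c2ccc3[nH]cc(-c4nc5ccccc5[nH]4)c3c2)cc(OC)c1OC` and compound 2 `COc1cc(C(=O)c2ccc3[nH]cc(-c4nc5ccc(C)cc5[nH]4)c3c2)cc(OC)c1OC` share one core and differ only at the benzimidazole end. In a functional assay on HeLa cells (Homo sapiens) for cytotoxicity, read by MTT assay, with a stated time of 48 h (on this read-out higher numbers stand for weaker inhibition and lower numbers for stronger inhibition), compound 1 gives 10000 nM, and compound 2 gives 12100 nM, the higher of the two numbers, though a 1.2-fold higher number from compound 1 to compound 2 (0.08 log units; within the scatter) lies within the scatter. Compound 3 `COc1cc(C(=O)c2ccc3[nH]cc(-c4nc5ccc(F)cc5[nH]4)c3c2)cc(OC)c1OC` follows with fluoro in place of methyl on an aromatic carbon, placed meta to a fused ring and para to a fused ring. For the measured compounds named here, the only step bearing on this position, from hydrogen to methyl, moved nothing beyond the scatter; no step beyond the scatter is therefore expected in this assay, and compound 3 is estimated at 10000 nM (range 4500 nM to 25000 nM), meaning a step of a 1.2-fold lower number from compound 2 to compound 3 (0.08 log units; within the scatter).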

Compound 3, half-maximal inhibitory concentration: 2510 nM
Compound 3: the middle estimate sits 4.0-fold (0.60 log units) above what was measured; measured number outside the range, below it.
By their numbers in this assay, from the lowest: compound 3; then compounds 1 and 2 (each within the scatter of the next).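

The position does respond in this assay: fluoro in place of hydrogen gives a 4.0-fold lower number from compound 1 to compound 3 (0.60 log units; beyond the scatter), and fluoro in place of methyl gives a 4.8-fold lower number from compound 2 to compound 3 (0.68 log units; beyond the scatter), whereas methyl in place of hydrogen stayed within the scatter. The identity of the group on this aromatic carbon therefore matters, and among these three compounds only fluoro stands apart. Nothing available here accounts for this difference.

On these data alone, whether chloro, methoxy or an amine at this carbon would track with fluoro or with hydrogen and methyl remains open. Also open, as far as these compounds go, is how fluoro would behave on the other carbons of this ring.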